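Nitrothienopyrimidinone amines: Vero cytotoxicity, ethyl to cyclopentyl

The source may report more compounds than this note shows. Statements on the series, on what has been measured and on what is new or still open speak of the compounds shown alone.

Working notes on the series. Three compounds share the core, two of them without a reading: compound 1 `CC(C)CNc1nc(=O)c2cc([N+](=O)[O-])cc([N+](=O)[O-])c2s1` and compound 2 `CC(C)(C)Nc1nc(=O)c2cc([N+](=O)[O-])cc([N+](=O)[O-])c2s1`. In an ADME assay on Vero cells (Chlorocebus sabaeus) for cytotoxicity, read by MTT assay, with a stated time of 72 h (on this read-out lower numbers stand for stronger inhibition and higher numbers for weaker inhibition), compound 1 gives "not determined" (no result reported). In this assay compound 2 likewise gives "not determined" (no result reported). Within the data shown here, the only number-bearing entry is compound 3 `CCNc1nc(=O)c2cc(C(F)(F)F)cc([N+](=O)[O-])c2s1`. For compound 3 the reading in this assay is a limit of the assay, > 100000 nM. Where compound 3 stands is therefore set by the limit of > 100000 nM in this assay, at which 1 of the 3 values shown sits, and not by a measured midpoint; no step between measured compounds is available.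

Compound 4 `O=c1nc(NC2CCCC2)sc2c([N+](=O)[O-])cc(C(F)(F)F)cc12` is the next analogue, the change being cyclopentyl in place of ethyl on a nitrogen on an aromatic ring. Among the measured compounds shown here, with no measured step to lean on, the expectation for a number no higher from compound 3 to compound 4 (the limit leaves the size open) is no step beyond the scatter, in either direction. Compound 4 is estimated at 100000 nM, within 40000 nM to 300000 nM, and most likely compound 4 is reported as a limit again.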

Compound 4, half-maximal inhibitory concentration: > 100000 nM
Compound 4 was reported as a limit; the forecaster's own chance of this, stated with the estimate: 70%; the middle value lies on the limit itself.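

No step can be read between compound 3 and compound 4 in this assay, because both readings are limits of the assay: the limit of > 100000 nM in this assay, at which 2 of the 4 values shown sit.

The compounds shown leave open how ethylamino and cyclopentylamino compare in this assay, and whether any compound on the shared core gives a midpoint there.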